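This account rests on a few compounds, and the source may have more. Where it says the series, first, only, none or still open, it means among the compounds named here.

Going by the values given here, in a physicochemical assay for acid dissociation, compound 2 `CCc1nc2c(C)cc(C)nc2n1Cc1ccc(-c2ccccc2C(=O)O)cc1` gives 5.1, the lowest of the two numbers known; in this assay compound 1 `CCc1nc2c(C)cc(C)nc2n1Cc1ccc(-c2ccccc2C2=NN(c3ccccc3)[S+]([O-])N2)cc1` gives 7.1. Compound 3 `CCc1nc2c(C)cc(C)nc2n1Cc1ccc(-c2ccccc2N2N=C(c3ccccc3)N[S+]2[O-])cc1` differs from compound 2 in one place: a group of 12 heavy atoms (7 carbon, 3 nitrogen, 1 oxygen, 1 sulfur; one five-membered non-aromatic ring with 4 hetero atoms, one six-membered aromatic ring of carbon only) in place of a group of 3 heavy atoms (1 carbon, 2 oxygen; no ring), on an aromatic carbon. Among the compounds with values here, the only measured step that bears on this runs the opposite way, a number 2.00 log units lower from compound 1 to compound 2 (beyond the scatter), where a closely related ring group gave way to the carboxy. Putting such a group back in place of the carboxy is therefore expected to raise the number by about as much, a step of a number 1.90 log units higher from compound 2 to compound 3 (beyond the scatter). For compound 3 the estimate is 7, with a range from 6 to 8.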

Compound 3, acid dissociation constant: about 7.1
Estimate against measurement, compound 3: 0.10 log units below; the measured number falls inside the stated range.
By their numbers in this assay, from the lowest: compound 2; then compounds 1 and 3 (each within the scatter of the next).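

In this assay, the ring group carrying a phenyl on this aromatic carbon stands well apart from the carboxy, with a number 2.00 log units higher from compound 2 to compound 3 (beyond the scatter). The two ring groups have the same atom counts but are built and attached differently, and they give no change at the digits printed from compound 1 to compound 3 (within the scatter), so that difference in the ring does not show in this read-out. No measurement here explains either step.

On these data alone, what a tetrazole or an amide on this aromatic carbon would give remains open. So does whether a ring group without the phenyl would stay near compound 3 or come closer to compound 2.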